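Ethyl on the furan ring: from compound 2 to compound 3

The source may hold more compounds than are shown below. What is called first, only, known or untested is meant among the compounds shown, and "the series" means these compounds.

Compound 1 `Clc1ccc(/C=N/N(Cc2ccccc2)Cc2ccccc2)cc1`: 240 nM
Compound 2 `C(=N/N(Cc1ccccc1)Cc1ccccc1)\c1ccco1`: 1100 nM

Among the measured compounds shown here, in an assay on liver (Sus scrofa) for inhibition of glucose-6-phosphatase catalytic subunit 1 (Homo sapiens), using microsomes (on this read-out lower numbers stand for stronger inhibition and higher numbers for weaker inhibition), compound 2 gives the highest of the two numbers measured so far; the nearest is compound 1, and the step of a 4.6-fold higher number from compound 1 to compound 2 (0.66 log units; beyond the scatter) is the only one known. Compound 3 `CCc1ccc(/C=N/N(Cc2ccccc2)Cc2ccccc2)o1` differs from compound 2 by ethyl in place of hydrogen on an aromatic carbon. For the measured compounds named here, no measured step covers an added ethyl; the one known step swaps the whole ring, so it bears only loosely here. A small change, likely within the usual scatter, is expected, a 1.4-fold lower number from compound 2 to compound 3 (0.14 log units; within the scatter). For compound 3 the estimate is 800 nM, between 300 nM and 2500 nM.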

Compound 3, half-maximal inhibitory concentration: 330 nM
For compound 3 the middle estimate is 2.4-fold (0.38 log units) above the measured one; the measured number falls inside the stated range.
By their numbers in this assay, from the lowest: compounds 1 and 3 (each within the scatter of the next); then compound 2.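

In this assay, ethyl in place of hydrogen on the aromatic carbon next to the ring oxygen gives a clear change (a 3.3-fold lower number from compound 2 to compound 3 (0.52 log units; beyond the scatter)), so the number responds to a group at this position of the furan ring. With this ethyl present, the ring swap no longer gives a step beyond the scatter (a 1.4-fold higher number from compound 1 to compound 3 (0.14 log units; within the scatter)). Nothing measured here bears on the reason for this. On these data alone, whether a longer chain such as propyl, or an amine, at this position would give a lower number or a higher one remains open.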